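Bromo for aminomethyl on the chain of compound 1

The source may report more compounds than this note shows. Statements on the series, on what has been measured and on what is new or still open speak of the compounds shown alone.

In an ADME assay on MDCK cells (Canis lupus familiaris) for cytotoxicity, read by MTT assay, with a stated time of 2 days (a higher number here means that more compound is tolerated, a lower number that less compound is tolerated), compound 1 (`NCCCCc1ccc(-c2ccc(-c3cccs3)s2)s1`) gives 13300 nM. Compound 2 (`NCCCCc1ccc(-c2ccc(-c3ccc(CCCCN)s3)s2)s1`) gives 13000 nM, and compound 3 (`NCCCCc1ccc(-c2ccc(CCCCN)s2)s1`) gives 26500 nM. Compound 1 therefore stands within the scatter of both: the nearest is a 1.0-fold lower number from compound 1 to compound 2 (0.01 log units; within the scatter), and the furthest is a 2.0-fold higher number from compound 1 to compound 3 (0.30 log units; within the scatter).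

Compound 4 (`BrCCCc1ccc(-c2ccc(-c3cccs3)s2)s1`) has not yet been measured. Its change from compound 1 is bromo in place of aminomethyl on a saturated chain carbon, three bonds along the chain from an aromatic carbon, which turns 4-aminobutyl into 3-bromopropyl. Neither measured step bears on it directly, since compounds 1, 2 and 3 all carry 4-aminobutyl and none shows what happens when that group is lost. For the measured compounds named here, the only indirect guide is that adding a further 4-aminobutyl gave a 1.0-fold lower number from compound 1 to compound 2 (0.01 log units; within the scatter) and a 2.0-fold higher number from compound 1 to compound 3 (0.30 log units; within the scatter), both within the scatter. On that thin basis, no change beyond the scatter is expected, though with wide uncertainty. The expected step is a 1.1-fold higher number from compound 1 to compound 4 (0.05 log units; within the scatter). For compound 4 the estimated value is 15000 nM, with an expected range from 5000 nM to 60000 nM.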

Compound 4, half-maximal cytotoxic concentration: 35300 nM
Compound 4: middle estimate off by 2.4-fold (0.37 log units), on the low side; the measured number falls inside the stated range.
By their numbers in this assay, from the lowest: compounds 2, 1, 3 and 4 (each within the scatter of the next, the first and the last beyond it).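

In this assay, bromo in place of aminomethyl on a saturated chain carbon, three bonds along the chain from an aromatic carbon, gives a 2.7-fold higher number from compound 1 to compound 4 (0.42 log units; beyond the scatter) as a modest step. It is the only step shown that lies beyond the scatter, and the only one that alters the 4-aminobutyl chain of compound 1 rather than the group at the far end of the core, so this chain is a place where a change registers in this read-out, toward more compound being tolerated. Nothing measured here accounts for the rise.

The compounds shown leave open whether the step follows the loss of the amine, the arrival of the bromine or the shorter chain. A 4-bromobutyl chain, a 3-hydroxypropyl chain or a plain propyl chain would tell these apart.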